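Removing the 1-(methoxycarbonyl)-2-methylpropyl group from compound 1

A few compounds are considered here, and "the series" means these few. Any claim that something is new, unique, unknown or untested is made for them only; others in the source may bear on it.

Among the measured compounds shown here, in an ADME assay on MDCK cells (Canis lupus familiaris) for cytotoxicity, read by MTT assay, with a stated time of 48 h (on this read-out higher numbers stand for lower toxicity in this test and lower numbers for higher toxicity in this test), compound 1 (`COC(=O)[C@@H](NC(=O)CSc1nc(-c2ccccc2)cc(-c2ccc(C)cc2)c1C#N)C(C)C`) gives 210000 nM as the only number so far. Compound 2 (`COC(=O)[C@H](CCCNC(=N)N)NC(=O)CSc1nc(-c2ccccc2)cc(-c2ccc(C)cc2)c1C#N`) reports > 250000 nM as a limit of the assay and not a number. Compound 3 (`Cc1ccc(-c2cc(-c3ccccc3)nc(SCC(N)=O)c2C#N)cc1`) carries the change hydrogen in place of 1-(methoxycarbonyl)-2-methylpropyl on an amide-type nitrogen and so keeps only the carbamoyl on the shared core. For the measured compounds named here, one measured step bears on this, an at least 1.1-fold higher number from compound 1 to compound 2 (0.07 log units; that floor lies within the scatter) and it replaces a group on the saturated chain carbon rather than removing the whole substituent from the amide-type nitrogen. It therefore offers only indirect guidance, and no large change is indicated. The expected step is a 1.4-fold lower number from compound 1 to compound 3 (0.15 log units; within the scatter) and it is not expected to exceed the scatter. In this assay the estimated value for compound 3 is 150000 nM and the expected range runs from 60000 nM to 250000 nM on present data.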

Compound 3, half-maximal cytotoxic concentration: > 250000 nM
Compound 3 was reported as a limit; the forecaster's own chance of this, stated with the estimate: 30%; at least 1.6-fold (0.22 log units) between middle value and limit.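

In this assay compound 3 is reported at > 250000 nM, which is a limit of the assay and not a number. Replacing the whole 1-(methoxycarbonyl)-2-methylpropyl group on the amide-type nitrogen with hydrogen gives an at least 1.1-fold higher number from compound 1 to compound 3 (0.07 log units; that floor lies within the scatter), so this position now has a measured case of full removal, where the earlier step only exchanged a group on the saturated chain carbon, and no drop in the number appears. The step between compound 2 and compound 3 cannot be read, and the room for any comparison at this position is narrow: the limit of > 250000 nM in this assay, at which 2 of the 3 values shown sit.

Still open, as far as these compounds go, is how far compound 2 and compound 3 lie past that limit. Also open, from the compounds shown here alone, is whether a carboxylic acid in place of the methyl ester, or an amine on the amide-type nitrogen, would give a number that can be read.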